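Varying the group on the aromatic oxygen

The source may hold more compounds than are shown below. What is called first, only, known or untested is meant among the compounds shown, and "the series" means these compounds.

In a functional assay on A549 cells (Homo sapiens) for antiproliferative activity, read by MTT assay, with a stated time of 48 h (a lower number here means a stronger inhibitor, a higher number a weaker inhibitor), three compounds that differ only in the group on an oxygen on an aromatic ring have been measured. Compound 1 `CCOc1cc(-c2ccc3c(ccn3C)c2)cn2c(-c3cc(OC)c(OC)c(OC)c3)nnc12`, with ethyl, gives 334 nM. Compound 2 `COc1cc(-c2nnc3c(OC4COC4)cc(-c4ccc5c(ccn5C)c4)cn23)cc(OC)c1OC`, with oxetan-3-yl, gives 516 nM. Compound 3 `COc1cc(-c2nnc3c(OC4CCC4)cc(-c4ccc5c(ccn5C)c4)cn23)cc(OC)c1OC`, with cyclobutyl, gives 176 nM. Compound 3 sits within the scatter of compound 1, as shown by a 1.9-fold lower number from compound 1 to compound 3 (0.28 log units; within the scatter), and only compound 2 stands clearly apart from it, as shown by a 2.9-fold lower number from compound 2 to compound 3 (0.47 log units; beyond the scatter).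

Compound 4 `CCCN1CC(Oc2cc(-c3ccc4c(ccn4C)c3)cn3c(-c4cc(OC)c(OC)c(OC)c4)nnc23)C1` carries 1-propylazetidin-3-yl in place of cyclobutyl at that oxygen: 1-propylazetidin-3-yl in place of cyclobutyl on an oxygen on an aromatic ring. For the measured compounds named here, the closest precedent is compound 2, which also has a four-membered ring with a hetero atom. Its step to cyclobutyl is modest, and a 1.5-fold higher number from compound 1 to compound 2 (0.19 log units; within the scatter) stays within the scatter. Going by the values given here, no measured compound has a ring nitrogen or a propyl group, so the precedent is only partial and the range must stay wide. A small move towards a higher number is expected, likely not beyond the scatter, and the expected step is a 1.7-fold higher number from compound 3 to compound 4 (0.23 log units; within the scatter). For compound 4 the estimated value is 300 nM, with an expected range of 100 nM to 900 nM.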

Compound 4, half-maximal inhibitory concentration: 234 nM
The estimate for compound 4 lay 1.3-fold (0.11 log units) above the measured number, and the stated range covers the measured number.
By their numbers in this assay, from the lowest: compounds 3, 4, 1 and 2 (each within the scatter of the next, the first and the last beyond it).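

Notes on the group on an oxygen on an aromatic ring: in this assay, this position accepts 1-propylazetidin-3-yl, which brings a ring nitrogen and a propyl group not seen in the earlier compounds, with no change beyond the scatter against cyclobutyl (a 1.3-fold higher number from compound 3 to compound 4 (0.12 log units; within the scatter)) or against ethyl (a 1.4-fold lower number from compound 1 to compound 4 (0.15 log units; within the scatter)). For the compounds shown here, a hetero atom in the four-membered ring therefore does not by itself place a compound with oxetan-3-yl, since the step from that group to 1-propylazetidin-3-yl is modest but beyond the scatter (a 2.2-fold lower number from compound 2 to compound 4 (0.34 log units; beyond the scatter)); compound 2 remains the only member of the series set apart, and compound 1 sits within the scatter of compound 4. Nothing available accounts for these differences in terms of a measured property of the groups.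

The contributions of the ring nitrogen and the propyl group remain unseparated, and an azetidin-3-yl with a free ring amine or with a methyl in place of the propyl would divide them. Going by these compounds, how far the position extends is also open, for example with a longer chain on the ring nitrogen or a carboxylic acid at its end.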